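From 3,4-dichlorophenoxy to (4-fluorophenyl)sulfanyl on a diamine core

This account rests on a few compounds, and the source may have more. Where it says the series, first, only, none or still open, it means among the compounds named here.

Measured so far:
Compound 1 `Nc1cc(N)c2nc(-c3ccccc3)c(Oc3ccc(Cl)c(Cl)c3)nc2c1`: 47900 nM
Compound 2 `CCOC(=O)[C@H](CCC(=O)O)NC(=O)c1ccc(CNc2nc3cc(N)cc(N)c3nc2-c2ccccc2)cc1`: < 100000 nM (a limit, not a number)

Going by the values given here, compound 1 `Nc1cc(N)c2nc(-c3ccccc3)c(Oc3ccc(Cl)c(Cl)c3)nc2c1` is the one compound with a number in a functional assay on ACHN cells (Homo sapiens) for inhibition, read by sulforhodamine B assay, with a stated time of 48 h (a lower number here means a stronger inhibitor of growth, a higher number a weaker inhibitor of growth), where compound 1 gives 47900 nM. Compound 2 `CCOC(=O)[C@H](CCC(=O)O)NC(=O)c1ccc(CNc2nc3cc(N)cc(N)c3nc2-c2ccccc2)cc1` gives only a limit in this assay, reported as < 100000 nM. So compound 1 stands alone on the numbers; the second value is a limit of < 100000 nM in this assay, at which 1 of the 2 values shown sits, and cannot be ranked against it.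

Compound 3 `Nc1cc(N)c2nc(-c3ccccc3)c(Sc3ccc(F)cc3)nc2c1` has not been measured. It differs from compound 1 in one place: (4-fluorophenyl)sulfanyl in place of 3,4-dichlorophenoxy on an aromatic carbon. Among the compounds with values here, no pair of measured compounds shows the effect of such a change, so there is no measured step to lean on. The expected step of a 1.2-fold lower number from compound 1 to compound 3 (0.08 log units; within the scatter) is expected to lie within the usual scatter, in no firm direction. Compound 3 is therefore estimated at 40000 nM, with a range from 10000 nM to 150000 nM.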

Compound 3, concentration for total growth inhibition: < 100000 nM
Compound 3: no number, only a limit; the forecaster's own chance of this, stated with the estimate: 30%; the middle value is on the limit's open side.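

Compound 3 gives only a limit, < 100000 nM, and not a number, so the change from compound 1 to compound 3 cannot be read as a step: the limit of < 100000 nM in this assay, at which 2 of the 3 values shown sit.

On these data alone, whether (4-fluorophenyl)sulfanyl in place of 3,4-dichlorophenoxy on the shared core gives a stronger or weaker inhibitor of growth remains open.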